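Anilinoquinone series: shifting the aryl ether substituent

This account rests on a few compounds, and the source may have more. Where it says the series, first, only, none or still open, it means among the compounds named here.

Measured compounds:
compound 1 `O=C1C(Nc2cccc(Cl)c2)=CC(=O)c2c1nc1n2[C@H]2OC[C@@H](O)[C@H]2OC1` — 3080 nM
compound 2 `COc1cccc(NC2=CC(=O)c3nc4n(c3C2=O)[C@H]2OC[C@@H](O)[C@H]2OC4)c1` — 7620 nM
compound 3 `Cc1ccc(NC2=CC(=O)c3c(nc4n3[C@H]3OC[C@@H](O)[C@H]3OC4)C2=O)cc1` — limit, > 4000 nM

In a functional assay on ECa-109 cells for inhibition, with ECa-109 cell line (Homo sapiens) as the target, read by sulforhodamine B assay (on this read-out lower numbers stand for stronger inhibition and higher numbers for weaker inhibition), compound 1 gives 3080 nM and compound 2 gives 7620 nM. For compound 3 only a limit is recorded, > 4000 nM; this is described by the limit of > 4000 nM in this assay, at which 1 of the 3 values shown sits. Among the two numbers, compound 2 stands highest, with compound 1 as its nearest neighbour at a lower number, a gap beyond the scatter.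

Among the compounds with values here, the one step measured within the shared core, an at least 1.2-fold higher number from compound 1 to compound 3 (0.11 log units; that floor lies within the scatter), is a swap of one aryl substituent for another; its floor lies within the scatter, so it shows no secure movement. Compound 4 `CCOc1ccccc1NC1=CC(=O)c2nc3n(c2C1=O)[C@H]1OC[C@@H](O)[C@H]1OC3` differs from compound 2 as follows: 2-ethoxyphenyl in place of 3-methoxyphenyl on an amine nitrogen. Within the data shown here, no measured step swaps one alkoxy for another, so the single aryl step is the only guide, and it points to little movement in this assay.

For compound 4 the estimate in this assay is 8000 nM, with a range from 3000 nM to 20000 nM. The expected step is a 1.0-fold higher number from compound 2 to compound 4 (0.02 log units; within the scatter), which stays within the scatter.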

Compound 4, half-maximal inhibitory concentration: 4630 nM
The estimate for compound 4 lay 1.7-fold (0.24 log units) above the measured number; the measured number falls inside the stated range.
By their numbers in this assay, from the lowest: compounds 1, 4 and 2 (each within the scatter of the next, the first and the last beyond it).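

In this assay, 2-ethoxyphenyl in place of 3-methoxyphenyl on the amine nitrogen gives a 1.6-fold lower number from compound 2 to compound 4 (0.22 log units; within the scatter), so this swap between two alkoxy-bearing aryl groups brings no secure movement. Unlike the earlier aryl step, which ends in a limit, this step has a measured number at both ends, so the lack of secure movement rests on two real values. The data shown give no cause for this step.

Still open, going by these compounds, is how the series responds when an amine or a carboxylic acid replaces the alkoxy group on the aryl ring, or when a longer chain such as butoxy does. Compound 3 remains a limit, so its place among the other compounds stays unresolved: the limit of > 4000 nM in this assay, at which 1 of the 4 values shown sits.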